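The source may hold more compounds than are shown below. What is called first, only, known or untested is meant among the compounds shown, and "the series" means these compounds.

Compound 1 `COc1ccc(-c2cc(/C=C/C(=O)c3ccc(N)cc3)[nH]n2)cc1`: 81%
Compound 2 `COc1ccc(C(=O)/C=C/c2cc(-c3cc(OC)c(OC)c(OC)c3)n[nH]2)cc1`: 92%
Compound 3 `COc1cc(-c2cc(/C=C/C(=O)c3ccc(F)c(F)c3)[nH]n2)cc(OC)c1OC`: 85%

Of the compounds shown here, three have been measured in a functional assay on TK-10 cells (Homo sapiens) for cytotoxicity, read by sulforhodamine B assay, with a stated time of 48 h, tested at 1 uM; on this read-out lower numbers stand for a stronger effect and higher numbers for a weaker effect at the one concentration tested. Compound 1 stands lowest of the three numbers; its nearest neighbour is compound 3, which lies within the scatter of it, while compound 2 lies furthest from it and beyond the scatter. For the measured compounds named here, the only step between measured compounds that differ in one place is a number 7 percentage points lower from compound 2 to compound 3 (within the scatter), a swap on a carbonyl carbon that stays within the scatter.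

Compound 4 `COc1ccc(-c2cc(/C=C/C(=O)c3ccc(N)cc3)[nH]n2)cc1OC` has not yet been measured. It differs from compound 1 by methoxy in place of hydrogen on an aromatic carbon, the new group sitting ortho to a methoxy group and meta to a large group. Going by the values given here, no measured step touches this place: compounds 2 and 3 carry a trimethoxyphenyl group on the shared core where compound 1 carries a methoxyphenyl group, but they differ from compound 1 in more than one place, so their values, which lie above that of compound 1, cannot be read as the effect of added methoxy groups alone. Among the compounds with values here, with the one single-place step within the scatter and no direct precedent, no step beyond the scatter is expected here, so a number 3 percentage points higher from compound 1 to compound 4 (within the scatter) is the estimated change. Compound 4 is therefore expected to give about 84% in this assay, estimated between 70% and 98%.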

Compound 4, a percentage reported as activity, at one concentration (the size of the read-out at that concentration, not a potency): 107%
Compound 4: the middle estimate sits 23 percentage points below what was measured; the measured number lies above the stated range.
By their numbers in this assay, from the lowest: compounds 1, 3 and 2 (each within the scatter of the next, the first and the last beyond it); then compound 4.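

In this assay, the change gives a number 26 percentage points higher from compound 1 to compound 4 (beyond the scatter), with methoxy in place of hydrogen on an aromatic carbon, ortho to a methoxy group and meta to a large group, and the direction is towards a weaker effect at the one concentration tested. For the compounds shown here, the only earlier single-place step, a number 7 percentage points lower from compound 2 to compound 3 (within the scatter), concerned a group on a carbonyl carbon, so this is the first single-place change to move the read-out beyond the scatter, and it shows that this aromatic carbon does not tolerate every substituent without consequence. Nothing available explains why the added methoxy has this effect.

The compounds shown carry only hydrogen or methoxy at this place, so they leave open whether a smaller group such as fluorine or hydroxy on the same carbon would shift the read-out in the same way, or whether the shift is particular to methoxy. They also leave open whether the same step would be seen with a group other than the aminophenyl on the carbonyl, such as the 3,4-difluorophenyl of compound 3.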